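The compounds below may be only part of what the source reports. "The series", "measured", "known", "first", "only" and "open" are said of these compounds alone.

Compound 2 `O=C([C@@H]1CCCN(S(=O)(=O)c2ccc(S(=O)(=O)N3CC[C@@H](O)C3)cc2)C1)N1CCC(F)(F)CC1` gives 330 nM in a functional assay on BXPC-3 cells (Homo sapiens) for inhibition, read by MTT assay, with a stated time of 7 days (a lower number here means a stronger inhibitor, a higher number a weaker inhibitor), the lowest of the three numbers in hand. Compound 1 `CCN(CC)S(=O)(=O)c1ccc(S(=O)(=O)N2CCC[C@@H](C(=O)N[C@H]3CC[C@H](OC)CC3)C2)cc1` gives 2000 nM, and compound 3 `CCN(CC)S(=O)(=O)c1ccc(S(=O)(=O)N2CCC[C@@H](C(=O)N3CCC(O)CC3)C2)cc1` gives 4710 nM. Going by the values given here, the one step between compounds that differ in a single place, a 2.4-fold higher number from compound 1 to compound 3 (0.37 log units; beyond the scatter), concerns the carbonyl side of the shared core and does not touch the sulfonyl substituent. Compound 4 `CCC(CC)S(=O)(=O)c1ccc(S(=O)(=O)N2CCC[C@@H](C(=O)N3CCC(F)(F)CC3)C2)cc1` differs from compound 2 by pentan-3-yl in place of 3-hydroxypyrrolidin-1-yl on a sulfonyl sulfur. Among the compounds with values here, no measured step bears on this change; the two compounds without a hydroxyl on the sulfonyl-bound group, compound 1 and compound 3, both sit well above compound 2, but they also differ on the carbonyl side. A weaker number is therefore expected, with wide uncertainty, so compound 4 is estimated at 1500 nM (range 400 nM to 6000 nM), a step of a 4.5-fold higher number from compound 2 to compound 4 (0.66 log units; beyond the scatter).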

Compound 4, half-maximal inhibitory concentration: 40 nM
Estimate against measurement, compound 4: 38-fold (1.57 log units) above, outside the stated range (below it).
By their numbers in this assay, from the lowest: compound 4; then compound 2; then compound 1; then compound 3.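

At the place on a sulfonyl sulfur whose other neighbour is aromatic carbon, the change to open-chain pentan-3-yl in this assay gives an 8.3-fold lower number from compound 2 to compound 4 (0.92 log units; beyond the scatter). The ring, hydroxyl, nitrogen and hydrogen-bond donor of 3-hydroxypyrrolidin-1-yl are therefore not required for a low number in this pair. No available evidence accounts for the size of this step.

Going by these compounds alone, the single change removes all these features together, so their separate contributions remain unresolved. Pyrrolidin-1-yl and cyclopentyl at this place would be the direct comparisons for separating them.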